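Replacing a two-ring group with 6-chloropyridin-2-yl

A few compounds are considered here, and "the series" means these few. Any claim that something is new, unique, unknown or untested is made for them only; others in the source may bear on it.

Compound 1 `CC(C)(C)Sc1c(CC(C)(C)C(=O)O)n(Cc2ccc(Cl)cc2)c2ccc(OCc3ccc4cc(F)c(F)cc4n3)cc12`: 7 nM
Compound 2 `CC(C)(C)Sc1c(CC(C)(C)C(=O)O)n(Cc2ccc(Cl)cc2)c2ccc(OCc3ccc4cccnc4n3)cc12`: 6 nM
Compound 3 `Cc1nc2ccc(COc3ccc4c(c3)c(SC(C)(C)C)c(CC(C)(C)C(=O)O)n4Cc3ccc(Cl)cc3)cc2s1`: 6 nM
Compound 4 `CC(C)(C)Sc1c(CC(C)(C)C(=O)O)n(Cc2ccc(Cl)cc2)c2ccc(OCc3cccc(Cl)n3)cc12`: not yet measured

In a functional assay for inhibition, with Homo sapiens as the target (a lower number here means a stronger inhibitor, a higher number a weaker inhibitor), compound 3 gives 6 nM and sits level with its nearest neighbour (no change at the digits printed from compound 2 to compound 3 (within the scatter)), while its furthest gap is also small (a 1.2-fold lower number from compound 1 to compound 3 (0.07 log units; within the scatter)). Compound 4 carries 6-chloropyridin-2-yl in place of 2-methyl-1,3-benzothiazol-6-yl on a saturated chain carbon bound to an oxygen on an aromatic ring. Three measured steps change the group at this same place: the two above and one more (a 1.2-fold lower number from compound 1 to compound 2 (0.07 log units; within the scatter)). All stayed within the scatter, yet each exchanged one group with two rings for another, so none shows what a single ring does here. Starting from compound 3 at 6 nM no step beyond the scatter is expected in this assay, though the missing evidence calls for caution. The estimated step is small (a 1.7-fold higher number from compound 3 to compound 4 (0.22 log units; within the scatter)) and leans toward a higher number. The estimate for compound 4 is 10 nM (expected range 3 nM to 35 nM) and that range is deliberately wide.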

Compound 4, half-maximal inhibitory concentration: 3 nM
The estimate for compound 4 lay 3.3-fold (0.52 log units) above the measured number, and the stated range covers the measured number.
By their numbers in this assay, from the lowest: compounds 4, 2, 3 and 1 (each within the scatter of the next, the first and the last beyond it).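

Compound 4 shows that a two-ring group is not required at this place, on a saturated chain carbon bound to an oxygen on an aromatic ring: in this assay, the single 6-chloropyridin-2-yl ring gives a 2.0-fold lower number from compound 3 to compound 4 (0.30 log units; within the scatter) and a 2.0-fold lower number from compound 2 to compound 4 (0.30 log units; within the scatter). The one gap beyond the scatter is modest, a 2.3-fold lower number from compound 1 to compound 4 (0.37 log units; beyond the scatter), so compound 4 stands level with compound 2 and compound 3 rather than clearly ahead of them. No measurement shown here explains how this single ring matches the two-ring groups.

A pyridin-2-yl without the chlorine, or with a methyl or a nitrile in its place, would show what the chlorine itself contributes. A 3-chlorophenyl ring would do the same for the ring nitrogen.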